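This account rests on a few compounds, and the source may have more. Where it says the series, first, only, none or still open, it means among the compounds named here.

Working notes on the series, read in a functional assay on MOLT-4 cells (Homo sapiens) for cytotoxicity, read by CCK-8 assay, with a stated time of 24 h; on this read-out higher numbers stand for weaker inhibition and lower numbers for stronger inhibition. Compound 1 `C=CC(=O)N1C(=O)CC(c2ccc(C(F)(F)F)cc2)Sc2ccccc21` gives 76300 nM, compound 2 `C=CC(=O)N1C(=O)CC(c2ccc(Cl)cc2)Sc2ccccc21` gives 82400 nM, and compound 3 `C=CC(=O)N1C(=O)CC(c2ccccc2C(F)(F)F)Sc2ccccc21` gives 84400 nM. All three values lie within the scatter of one another, so compound 3 stands level with the other two.

Compound 4 `C=CC(=O)N1C(=O)CC(c2ccccc2)Sc2ccccc21` follows from compound 3 by one change: hydrogen in place of trifluoromethyl on an aromatic carbon. Among the measured compounds shown here, the only measured step at a substituent is a 1.1-fold higher number from compound 1 to compound 2 (0.03 log units; within the scatter), chloro in place of trifluoromethyl, and it stays within the scatter. Compound 1 and compound 3 also carry trifluoromethyl at different places, and their values show no gap beyond the scatter. For the measured compounds named here, no measured compound tests hydrogen at this place, so the range is kept wide. In this assay, no step beyond the scatter is expected. The estimated step is a 1.0-fold higher number from compound 3 to compound 4 (0.00 log units; within the scatter). For compound 4 the estimated value is 85000 nM, with an expected range of 45000 nM to 160000 nM.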

Compound 4, half-maximal inhibitory concentration: 85900 nM
For compound 4 the middle estimate is 1.0-fold (0.00 log units) below the measured one, and the stated range covers the measured number.
By their numbers in this assay, from the lowest: compounds 1, 2, 3 and 4 (each within the scatter of the next).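

In this assay, among the compounds shown here, compound 4 gives the first reading with hydrogen on this aromatic carbon: hydrogen in place of trifluoromethyl reads as a 1.0-fold higher number from compound 3 to compound 4 (0.01 log units; within the scatter) and as a 1.1-fold higher number from compound 1 to compound 4 (0.05 log units; within the scatter), and hydrogen in place of chloro reads as a 1.0-fold higher number from compound 2 to compound 4 (0.02 log units; within the scatter). None of the three substituted compounds therefore separates from compound 4, so neither trifluoromethyl nor chloro is shown here to change the number relative to hydrogen. No supporting measurement is at hand to account for this flat reading.

The compounds shown leave open whether a group of another kind on this aromatic ring, such as an amine or a carboxylic acid, would give a step beyond the scatter. They also leave open whether a change in the shared core would move the number.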